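Nitro for Chloro on the Core of Compound 2

This account rests on a few compounds, and the source may have more. Where it says the series, first, only, none or still open, it means among the compounds named here.

The study assessed antiproliferative activity in a functional assay on HCT-116 cells (Homo sapiens) for antiproliferative activity, read by MTT assay, with a stated time of 72 h; on this read-out higher numbers stand for weaker inhibition and lower numbers for stronger inhibition. Going by the values given here, compound 2 `COc1ccc(/C=C2/CN(C)/C(=N/c3ccc(Cl)cc3)S2)cc1` is the only member of the set for which a number was obtained, and in this assay compound 2 gives 9800 nM. Compound 1 `COc1ccc(/C=C2\S/C(=N\c3ccc(C(C)(C)C)cc3)N(C)C2=O)cc1`, whose core carries a carbonyl that compound 2 lacks, reaches only a limit of the assay, and in this assay compound 1 gives > 100000 nM. Compound 3 `COc1ccc(/C=C2\S/C(=N\c3cc(C(F)(F)F)cc(C(F)(F)F)c3)N(C)C2=O)cc1`, built on that same carbonyl-bearing core with two trifluoromethyl groups on the aniline ring, likewise reaches only a limit, and in this assay compound 3 gives > 100000 nM. Thus two of the three results sit at the limit of > 100000 nM in this assay, at which 2 of the 3 values shown sit, and compound 2 stands alone with a measurable value.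

Compound 4 `COc1ccc(/C=C2/CN(C)/C(=N/c3ccc([N+](=O)[O-])cc3)S2)cc1` keeps the core of compound 2 and differs from it in one place: nitro in place of chloro on an aromatic carbon.

Among the compounds with values here, no step between measured compounds is available to calibrate this swap, so the expectation rests on compound 2 alone. Compound 4 is expected to stay close to compound 2, with a step of a 1.1-fold lower number from compound 2 to compound 4 (0.04 log units; within the scatter) that would not exceed the scatter. The estimate for compound 4 in this assay is therefore 9000 nM, within a range from 3000 nM to 30000 nM.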

Compound 4, half-maximal inhibitory concentration: 10200 nM
Compound 4: middle estimate off by 1.1-fold (0.05 log units), on the low side, and the stated range covers the measured number.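

In this assay, the aromatic carbon para to a large group tolerates the exchange of chloro for nitro, with a 1.0-fold higher number from compound 2 to compound 4 (0.02 log units; within the scatter). Going by these compounds alone, this is the first comparison in the set that changes one place only, and it shows that the activity of compound 2 does not depend on chloro being at this position, at least when the alternative is nitro, which brings hydrogen-bond acceptors that chloro lacks. Nothing measured here offers a reason why the two groups read alike.

From the compounds shown here alone, with only chloro and nitro to compare, it remains open whether an amine, a carboxylic acid or a methoxy group at the same carbon would also leave the number in place or move it in either direction. Going by these compounds, compound 1 and compound 3 differ from compound 2 in more than one place, so what the carbonyl on their core contributes also stays open, and a carbonyl-bearing compound with chloro or nitro on the aniline ring would be needed to separate that carbonyl from the aniline substituents.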